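The compounds below may be only part of what the source reports. "The series", "measured", "known", "first", "only" and "open" are said of these compounds alone.

In a functional assay on HepG2 cells (Homo sapiens) for cytotoxicity, read by sulforhodamine B assay, with a stated time of 48 h (on this read-out higher numbers stand for weaker inhibition and lower numbers for stronger inhibition), compound 2 (`COc1cc(/C=C/C(=O)c2ccc(N)c(-c3ccc(F)cc3)c2)ccc1O`) gives 4300 nM, compound 1 (`COc1cc(/C=C/C(=O)c2ccc(N)c(-c3ccc(F)cc3)c2)cc(Br)c1O`) gives 4730 nM and compound 3 (`COc1ccc(/C=C/C(=O)c2ccc(N)c(-c3ccc(F)cc3)c2)cc1OC`) gives 3780 nM. Compound 2 therefore stands within the scatter of both neighbours. Compound 4 (`Nc1ccc(C(=O)/C=C/c2ccc(O)c(F)c2)cc1-c1ccc(F)cc1`) carries fluoro in place of methoxy on an aromatic carbon, ortho to a hydroxy group: fluoro in place of methoxy on an aromatic carbon. Among the compounds with values here, no measured step makes this exchange. The closest evidence is hydrogen in place of bromo on an aromatic carbon, a 1.1-fold lower number from compound 1 to compound 2 (0.04 log units; within the scatter), and methyl in place of hydrogen on an oxygen, a 1.1-fold lower number from compound 2 to compound 3 (0.06 log units; within the scatter). Both steps are small, so no step beyond the scatter is expected in this assay. For compound 4 the estimated value is 4500 nM, with an expected range of 2200 nM to 9000 nM. The expected step is a 1.0-fold higher number from compound 2 to compound 4 (0.02 log units; within the scatter).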

Compound 4, half-maximal inhibitory concentration: 11700 nM
Compound 4: middle estimate off by 2.6-fold (0.41 log units), on the low side; measured number outside the range, above it.
By their numbers in this assay, from the lowest: compounds 3, 2 and 1 (each within the scatter of the next); then compound 4.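

In this assay, the exchange of 4-hydroxy-3-methoxyphenyl for 3-fluoro-4-hydroxyphenyl gives the only step shown beyond the scatter, a 2.7-fold higher number from compound 2 to compound 4 (0.43 log units; beyond the scatter). The bromo and hydroxy-methyl changes stayed within the scatter, so this position, ortho to a hydroxy group, is the one place shown where the number responds to the group it carries. No measurement on hand accounts for the step.

On these data alone, whether the loss of methoxy or the arrival of fluoro carries the step remains open. Hydrogen, chloro or ethoxy at this position could separate the two.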